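A Furan Swapped for a Pyrimidine on a Shared Core

The compounds below may be only part of what the source reports. "The series", "measured", "known", "first", "only" and "open" are said of these compounds alone.

Compound 2 `Fc1ccccc1Cn1nc(-c2ccco2)c2cccnc21` is tested in a functional assay (aorta) with Oryctolagus cuniculus as the target (on this read-out lower numbers stand for stronger inhibition and higher numbers for weaker inhibition), where compound 2 gives 9300 nM. Compound 1 `N#Cc1ccccc1Cn1nc(-c2ccc(CO)o2)c2ccccc21` gives 8700 nM, and compound 3 `NS(=O)(=O)c1ccc(-c2nn(Cc3ccccc3F)c3ncccc23)o1` gives 8000 nM; nothing separates compound 2 from either of them beyond the scatter. Compound 4 `Cc1cnc(-c2nn(Cc3ccccc3F)c3ncccc23)nc1N` differs from compound 2 in one place: 4-amino-5-methylpyrimidin-2-yl in place of furan-2-yl on an aromatic carbon. Going by the values given here, the only measured step in this region, a 1.2-fold lower number from compound 2 to compound 3 (0.07 log units; within the scatter), puts sulfamoyl in place of hydrogen on an aromatic carbon and leaves the ring itself untouched. Among the compounds with values here, no measured step exchanges the whole ring, so the expectation rests on little, and a step of a 1.6-fold lower number from compound 2 to compound 4 (0.19 log units; within the scatter) is expected, with wide uncertainty. Compound 4 is therefore estimated at 6000 nM, within 1500 nM to 25000 nM.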

Compound 4, half-maximal inhibitory concentration: 675000 nM
For compound 4 the middle estimate is 110-fold (2.05 log units) below the measured one; measured number above the stated range.
By their numbers in this assay, from the lowest: compounds 3, 1 and 2 (each within the scatter of the next); then compound 4.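

In this assay, replacing the whole ring on this aromatic carbon gives a 73-fold higher number from compound 2 to compound 4 (1.86 log units; beyond the scatter), a change far beyond the scatter. Adding sulfamoyl to the furan left the number within the scatter, at a 1.2-fold lower number from compound 2 to compound 3 (0.07 log units; within the scatter), so at this position the ring exchange matters far more than that one added group. No measurement available here accounts for the jump. Still open, on these data alone, is whether the six-membered ring itself or its amino and methyl groups carry the effect. A plain pyrimidin-2-yl at this place would help separate them.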